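Terminal amine deprotection and heteroaryl swap in one series

The source may report more compounds than this note shows. Statements on the series, on what has been measured and on what is new or still open speak of the compounds shown alone.

Compound 1 `Cc1cnc(C(=O)Nc2cc(OCCNC(=O)OC(C)(C)C)cc3cccnc23)cn1`: in a functional assay on PANC-1 cells (Homo sapiens) for inhibition, read by MTT assay, with a stated time of 72 h (a lower number here means a stronger inhibitor, a higher number a weaker inhibitor), compound 1 gives 2170 nM.
Compound 2 `Cc1cnc(C(=O)Nc2cc(OCCN)cc3cccnc23)cn1`: in this assay compound 2 gives only a limit, > 10000 nM.
Compound 3 `CC(C)(C)OC(=O)NCCOc1cc(NC(=O)c2ncccn2)c2ncccc2c1`: in this assay compound 3 gives only a limit, > 10000 nM.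

Two single changes from compound 1 are measured. The first, (hydrogen in place of tert-butoxycarbonyl on an amine nitrogen), gives an at least 4.6-fold higher number from compound 1 to compound 2 (0.66 log units; beyond the scatter), a step bounded by the limit of > 10000 nM in this assay, at which 2 of the 3 values shown sit. The second, (pyrimidin-2-yl in place of 5-methylpyrazin-2-yl on a carbonyl carbon), gives an at least 4.6-fold higher number from compound 1 to compound 3 (0.66 log units; beyond the scatter), again bounded by the limit of > 10000 nM in this assay, at which 2 of the 3 values shown sit.

Compound 4 `NCCOc1cc(NC(=O)c2ncccn2)c2ncccc2c1` is not yet measured. It differs from compound 3 by hydrogen in place of tert-butoxycarbonyl on an amine nitrogen, the same change as from compound 1 to compound 2, at the same place. Compound 3 already sits at the limit, and in the measured pair the same change gave an at least 4.6-fold higher number from compound 1 to compound 2 (0.66 log units; beyond the scatter), so no recovery is expected for compound 4. The step to compound 4 is expected as a step that the limit leaves unreadable from compound 3 to compound 4. The estimate for compound 4 in this assay is 30000 nM, between 10000 nM and 100000 nM, most likely reported only as a limit.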

Compound 4, half-maximal inhibitory concentration: > 10000 nM
Compound 4: no number, only a limit; the forecaster's own chance of this, stated with the estimate: 90%; the middle value is on the limit's open side.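

Compound 4 also gives only a limit, so no step from compound 3 or compound 2 to compound 4 can be read: the limit of > 10000 nM in this assay, at which 3 of the 4 values shown sit.

On these data alone, how compound 2, compound 3 and compound 4 actually rank against one another remains open.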